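The source may hold more compounds than are shown below. What is called first, only, known or untested is meant among the compounds shown, and "the series" means these compounds.

The measured compounds:

Compound 1 `O=C(CSC(=S)N[C@H]1CCOC1=O)Nc1cccc(C(F)(F)F)c1`, in a functional assay on EC9706 cells (Homo sapiens) for cytotoxicity, read by MTT assay, with a stated time of 72 h (a lower number here means a stronger inhibitor, a higher number a weaker inhibitor), compound 1 gives 79700 nM.
Compound 2 `O=C(CSC(=S)N[C@H]1CCOC1=O)Nc1cccc([N+](=O)[O-])c1`, in this assay compound 2 gives a limit of > 128000 nM.
Compound 3 `O=C(CCl)Nc1ccc(C(=O)/C=C/c2ccc(Cl)cc2)cc1`, in this assay compound 3 gives 8340 nM.

Of the two numbers, compound 3 stands lowest; its nearest neighbour is compound 1, and the gap from compound 1 to compound 3 lies beyond the scatter. Compound 2 sits at a limit of this assay, (the limit of > 128000 nM in this assay, at which 1 of the 3 values shown sits), and gives no number.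

Compound 4 `O=C(CCl)Nc1ccc(C(=O)/C=C/c2ccc(F)cc2)cc1` differs from compound 3 by one change: fluoro in place of chloro on an aromatic carbon, that is, 4-chlorophenyl to 4-fluorophenyl. Among the measured compounds shown here, the only measured step, an at least 1.6-fold higher number from compound 1 to compound 2 (0.20 log units; that floor lies within the scatter), concerns a different core and a different pair of groups, and so says nothing about a change of one halogen for another on the aryl ring of compound 3. For the measured compounds named here, no measured step bears on this change. Compound 4 is therefore expected to give a number close to that of compound 3, with the step of a 1.3-fold higher number from compound 3 to compound 4 (0.12 log units; within the scatter) expected to lie within the scatter. The estimate for compound 4 in this assay is 11000 nM, with a range from 4000 nM to 35000 nM.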

Compound 4, half-maximal inhibitory concentration: 8600 nM
Compound 4: the middle estimate sits 1.3-fold (0.11 log units) above what was measured; measured number inside the range.
By their numbers in this assay, from the lowest: compounds 3 and 4 (each within the scatter of the next); then compound 1. At a limit, above all of these: compound 2.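

In this assay, the change from 4-chlorophenyl to 4-fluorophenyl gives a 1.0-fold higher number from compound 3 to compound 4 (0.01 log units; within the scatter), and this is the only step shown on the core shared by these two compounds. Among the compounds shown here, at this place, on an aromatic carbon para to a large group, the read-out therefore does not separate chloro from fluoro, whereas the earlier compounds offered no step on this core and no comparison of one halogen with another. Nothing in the evidence available bears on why the two halogens give values within the scatter of each other.

The compounds shown leave open whether this place accepts groups other than these two halogens, such as an amine, a methoxy group or a carboxylic acid, or whether a bare hydrogen there would give a value in the same range. They also leave open how much the chloroacetyl group at the other end of the core matters, as a plain acetyl group or a longer chain in its place would show.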